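Pyridone nitrile series: a substituent on the ring nitrogen

The source may hold more compounds than are shown below. What is called first, only, known or untested is meant among the compounds shown, and "the series" means these compounds.

Compound 1 `Cn1cccc1-c1cc(-c2ccc(Br)cc2)[nH]c(=O)c1C#N` is one of three pyridone nitriles measured in a functional assay on UO-31 cells (Homo sapiens) for cytotoxicity, read by sulforhodamine B assay, with a stated time of 48 h; on this read-out higher numbers stand for weaker inhibition of growth and lower numbers for stronger inhibition of growth. In this assay compound 1 gives 69200 nM, the lowest of the two numbers reported, while compound 2 `COc1ccc(-c2cc(-c3cccn3C)c(C#N)c(=O)[nH]2)cc1OC` gives 85100 nM, a value within the scatter of that of compound 1. Compound 3 `COc1ccc(-c2cc(-c3cccs3)[nH]c(=O)c2C#N)cc1` reaches only the limit of the assay, > 100000 nM, so that no number is known for it (the limit of > 100000 nM in this assay, at which 1 of the 3 values shown sits).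

Compound 4 `Cn1cccc1-c1cc(-c2ccc(Br)cc2)n(C(=S)Nc2ccc(F)cc2)c(=O)c1C#N` differs from compound 1 in one place: a group of 10 heavy atoms (7 carbon, 1 nitrogen, 1 fluorine, 1 sulfur; one six-membered aromatic ring of carbon only) in place of a hydrogen atom, on an aromatic nitrogen. Going by the values given here, no step between measured compounds covers a change of this kind, so its size is not told by the data. The account expects compound 4 to sit near compound 1, with any step from compound 1 to compound 4 of a 1.5-fold lower number from compound 1 to compound 4 (0.19 log units; within the scatter) hardly beyond the scatter. The estimate for compound 4 in this assay is 45000 nM, with a range from 12000 nM to 100000 nM.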

Compound 4, concentration for 50% growth inhibition: 13800 nM
Estimate against measurement, compound 4: 3.3-fold (0.51 log units) above, and the stated range covers the measured number.
By their numbers in this assay, from the lowest: compound 4; then compounds 1 and 2 (each within the scatter of the next). At a limit, above all of these: compound 3.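

Going by these compounds alone, in the earlier compounds this ring nitrogen carries only a hydrogen atom, so they showed nothing about a substituent at this position. In this assay, placing the group of 10 heavy atoms, with its six-membered aromatic ring of carbon only, on this aromatic nitrogen gives a 5.0-fold lower number from compound 1 to compound 4 (0.70 log units; beyond the scatter) and so shows that this position accepts a large group with stronger inhibition of growth, not weaker. Nothing given here bears on why the number falls.

On these data alone, whether the step belongs to the whole group or to one part of it remains open: a methyl or acetyl group on this nitrogen, or the same group with oxygen in place of sulfur, would bear on that. As far as these compounds go, it also remains open whether the same change would give a similar step on the cores of compound 2 and compound 3.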